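The source may hold more compounds than are shown below. What is called first, only, known or untested is meant among the compounds shown, and "the series" means these compounds.

In an ADME assay on BE(2)-C cells (Homo sapiens) for cytotoxicity, read by MTT assay, with a stated time of 20 h (on this read-out higher numbers stand for lower toxicity in this test and lower numbers for higher toxicity in this test), compound 1 `O=C(NCc1ccncc1)C1CCN(C(=O)c2cc3ccccc3n2Cc2ccc(Cl)cc2)CC1` gives > 100000 nM, which is a limit of the assay and not a number. For the measured compounds named here, compound 2 `CC(NC(=O)C1CCN(C(=O)c2cc3ccccc3n2Cc2ccc(Cl)cc2)CC1)c1ccncc1` gives 90100 nM, the only true number so far. Going by the values given here, the one measured step is an at least 1.1-fold lower number from compound 1 to compound 2 (0.04 log units; that floor lies within the scatter), and it concerns the methyl on the same saturated chain carbon.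

Compound 3 `C[C@@H](NC(=O)C1CCN(C(=O)c2cc3ccccc3n2Cc2ccc(Cl)cc2)CC1)c1ccncc1` brings the two compounds have the same atoms and bonds; at least one stereo element is drawn with a configuration in one of them and without one in the other: 1 of 1 stereo elements differ; a stereocentre at a saturated chain carbon is drawn without a configuration in compound 2 and R in compound 3: the two compounds have the same atoms and bonds, and the stereocentre at the saturated chain carbon is drawn without a configuration in compound 2 and R in compound 3. Among the compounds with values here, no measured step compares configurations at this carbon, and the step of an at least 1.1-fold lower number from compound 1 to compound 2 (0.04 log units; that floor lies within the scatter) offers no sign of a large change here. In this assay no shift beyond the scatter is expected, and no direction can be assigned. The expected step is a 1.1-fold lower number from compound 2 to compound 3 (0.03 log units; within the scatter). For compound 3 the estimated value is 85000 nM, with an expected range of 40000 nM to 130000 nM.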

Compound 3, half-maximal cytotoxic concentration: 92300 nM
Compound 3: middle estimate off by 1.1-fold (0.04 log units), on the low side; the measured number falls inside the stated range.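

In this assay, the R configuration drawn at the saturated chain carbon brings a 1.0-fold higher number from compound 2 to compound 3 (0.01 log units; within the scatter), so fixing this stereocentre in the drawing shows no shift beyond the scatter, and the comparison reaches no further than this: the fact that one of compounds 2 and 3 is drawn with a defined configuration and the other without, at the place where they differ. The methyl on the same carbon, now with the R configuration drawn, gives an at least 1.0-fold lower number from compound 1 to compound 3 (0.03 log units; that floor lies within the scatter), and this step is only a floor within the scatter. Compound 1 gives > 100000 nM, which is a limit of the assay and not a number: the limit of > 100000 nM in this assay, at which 1 of the 3 values shown sits.

Going by these compounds, the size of the methyl step therefore stays open, and so does the S configuration at this carbon. On these data alone, what an ethyl or a hydroxymethyl group on this saturated chain carbon would give in this assay also remains open.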